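The source may report more compounds than this note shows. Statements on the series, on what has been measured and on what is new or still open speak of the compounds shown alone.

Measured in a physicochemical assay for lipophilicity, at pH 7.4; on this read-out lower numbers stand for lower lipophilicity and higher numbers for higher lipophilicity:
Compound 1 `O=C(Nc1ccc2[nH]ncc2n1)[C@H]1COCCN1C(=O)C1(c2ccc(Cl)cc2)CC(F)(F)C1` gives 4.5
Compound 2 `O=C1Cc2cc(NC(=O)[C@H]3CCCN3C(=O)C3(c4cccc(Cl)c4)CCCC3)ccc2N1` gives 5

Compound 2 stands highest of the two at 5 on this scale, and compound 1 lies lower at 4.5 by a gap beyond the scatter. Compound 3 `CNC(=O)c1ccc(NC(=O)[C@H]2CCCN2C(=O)C2(c3cccc(Cl)c3)CCCC2)cc1` differs from compound 2 by a single change: a group of 10 heavy atoms (8 carbon, 1 nitrogen, 1 oxygen; one six-membered aromatic ring of carbon only) in place of a group of 10 heavy atoms (8 carbon, 1 nitrogen, 1 oxygen; one five-membered non-aromatic ring with 1 hetero atom, one six-membered aromatic ring of carbon only), on an amide-type nitrogen and the group that enters is 4-(methylcarbamoyl)phenyl. Among the compounds with values here, no measured pair shows this change, so no shift beyond the scatter is expected in this assay here. The estimated a number 0.10 log units lower from compound 2 to compound 3 (within the scatter) is small. For compound 3 the estimated value is 4.9 with an expected range from 4.4 to 5.4 in this measurement.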

Compound 3, distribution coefficient: 5.3
Compound 3: middle estimate off by 0.40 log units, on the low side; the measured number falls inside the stated range.
By their numbers in this assay, from the lowest: compound 1; then compounds 2 and 3 (each within the scatter of the next).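

In this assay, the first step read at this position, on an amide-type nitrogen, is a number 0.30 log units higher from compound 2 to compound 3 (within the scatter). Here 4-(methylcarbamoyl)phenyl takes the place of a group of equal heavy-atom count that carries a five-membered non-aromatic ring, so losing that ring gives no shift beyond the scatter in this pair. Nothing available here accounts for the step.

From the compounds shown here alone, whether a carboxylic acid or an amine in place of the methylcarbamoyl group would shift the number beyond the scatter remains open. So does whether the same change would behave alike on the core of compound 1.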